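Methoxy for chloro on the aryl-pyrimidinone arm

The compounds below may be only part of what the source reports. "The series", "measured", "known", "first", "only" and "open" are said of these compounds alone.

The measured compounds and their values:
compound 1, `Cc1nc(-c2ccc(Cl)cc2)sc1C(=O)CSc1nc(-c2ccc(Cl)c(Cl)c2)c(C#N)c(=O)[nH]1`, 36.5%
compound 2, `COc1ccc(-c2nc(C)c(C(=O)CSc3nc(-c4ccc(Cl)c(Cl)c4)c(C#N)c(=O)[nH]3)s2)cc1`, 31.1%
compound 3, `Cc1nc(-c2ccccc2)sc1C(=O)CSc1nc(N)c(C#N)c(-c2ccc(Cl)cc2)n1`, 17.1%

All three were tested in a functional assay on U-87MG ATCC cells for antiproliferative activity against U-87 MG (Homo sapiens), read by MTT assay, with a stated time of 48 h, tested at 100 uM; on this read-out lower numbers stand for a stronger effect and higher numbers for a weaker effect at the one concentration tested. Compound 1 gives the highest of the three numbers, that is the weakest effect shown. Its nearest neighbour is compound 2, reached by a number 5.4 percentage points lower from compound 1 to compound 2 (within the scatter), a step within the scatter, so no order between compound 1 and compound 2 can be read. Compound 3 stands further off, its value beyond the scatter from compound 1, and the two differ in more than one place, so only their two values can be set side by side.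

Compound 4, `COc1ccc(-c2nc(SCC(=O)c3sc(-c4ccc(Cl)cc4)nc3C)[nH]c(=O)c2C#N)cc1OC`, is not yet measured. It differs from compound 1 in one place: 3,4-dimethoxyphenyl in place of 3,4-dichlorophenyl on an aromatic carbon. Going by the values given here, the only measured step that resembles this change is the one from compound 1 to compound 2, where methoxy in place of chloro on an aromatic carbon, though on the other aryl ring, moved the number within the scatter. Nothing measured bears on the pyrimidinone arm itself. The expected step in this assay is therefore small, a number 2.5 percentage points lower from compound 1 to compound 4 (within the scatter), with no confident direction. Compound 4 is estimated at 34%, within the range 22% to 48%.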

Compound 4, a percentage reported as activity, at one concentration (the size of the read-out at that concentration, not a potency): 18.7%
For compound 4 the middle estimate is 15.3 percentage points above the measured one; measured number below the stated range.
By their numbers in this assay, from the lowest: compounds 3 and 4 (each within the scatter of the next); then compounds 2 and 1 (each within the scatter of the next).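

In this assay, putting 3,4-dimethoxyphenyl in place of 3,4-dichlorophenyl gives a number 17.8 percentage points lower from compound 1 to compound 4 (beyond the scatter), so this position, on the aromatic carbon ortho to a cyano group and next to the ring nitrogen, is one where the substituents on the aryl group change the read-out at the one concentration tested. The earlier step, a methoxy in place of a chloro on the other aryl ring, gave only a number 5.4 percentage points lower from compound 1 to compound 2 (within the scatter), so methoxy for chloro does not give one fixed outcome across the two arms, although the two changes also differ in the number of groups exchanged. No measurement shown accounts for the step or for the difference between the two arms.

The compounds shown leave open whether both methoxy groups are needed, or whether a lone 4-methoxy, a hydroxy or a dimethylamino group on that phenyl would give a similar number. They also leave open how an unsubstituted phenyl or an alkyl chain at this position would compare, and a reading at one concentration gives no potency for any of these compounds.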